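Shortening a Chloro Chain and Dropping a Bromo Group

A few compounds are considered here, and "the series" means these few. Any claim that something is new, unique, unknown or untested is made for them only; others in the source may bear on it.

Three related compounds have been tested in a functional assay on HeLa cells (Homo sapiens) for antiproliferative activity, read by MTT assay, with a stated time of 48 h; a lower number here means a stronger inhibitor, a higher number a weaker inhibitor. Compound 1 `O=C(CCl)Nc1ccc(SCC(=O)Nc2ccc(Br)cn2)cc1` gives 2100 nM in this assay. Compound 2 `O=C(CCl)Nc1ccc(SCC(=O)Nc2ccccn2)cc1` differs from compound 1 by hydrogen in place of bromo on an aromatic carbon. In this assay compound 2 gives 7800 nM, so a 3.7-fold higher number from compound 1 to compound 2 (0.57 log units; beyond the scatter). Compound 3 `O=C(CCCl)Nc1ccc(SCC(=O)Nc2ccc(Br)cn2)cc1` differs from compound 1 by chloromethyl in place of chloro on a saturated chain carbon bound to a carbonyl carbon. In this assay compound 3 gives 15600 nM, so a 7.4-fold higher number from compound 1 to compound 3 (0.87 log units; beyond the scatter). Compound 3 and compound 2 lie within the scatter of each other in this assay.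

Compound 4 `O=C(CCCl)Nc1ccc(SCC(=O)Nc2ccccn2)cc1` has not yet been measured. It differs from compound 3 by hydrogen in place of bromo on an aromatic carbon, the same change that turns compound 1 into compound 2, and made at the same place in both pairs; the two cores differ by chloromethyl in place of chloro on a saturated chain carbon bound to a carbonyl carbon. If the step in this assay repeats on the core of compound 3, compound 4 should give a weaker result than compound 3, and the expected step is a 3.2-fold higher number from compound 3 to compound 4 (0.51 log units; beyond the scatter), resting on the step from compound 1 to compound 2 of a 3.7-fold higher number from compound 1 to compound 2 (0.57 log units; beyond the scatter). The estimate for compound 4 in this assay is 50000 nM, expected to lie between 20000 nM and 120000 nM.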

Compound 4, half-maximal inhibitory concentration: 70400 nM
Estimate against measurement, compound 4: 1.4-fold (0.15 log units) below; measured number inside the range.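

In this assay, replacing 5-bromopyridin-2-yl with pyridin-2-yl on the core of compound 3 gives a 4.5-fold higher number from compound 3 to compound 4 (0.65 log units; beyond the scatter), matching the size of the same change on the core of compound 1: the same change on two cores in this assay, a 3.7-fold higher number (0.57 log units; beyond the scatter) from compound 1 to compound 2 and a 4.5-fold higher number (0.65 log units; beyond the scatter) from compound 3 to compound 4, 1.2-fold (0.08 log units) apart, within the scatter of two such steps

Putting chloromethyl in place of chloro on the chain also repeats, giving a 9.0-fold higher number from compound 2 to compound 4 (0.96 log units; beyond the scatter) on the core without the bromo group: the same change on two cores in this assay, a 7.4-fold higher number (0.87 log units; beyond the scatter) from compound 1 to compound 3 and a 9.0-fold higher number (0.96 log units; beyond the scatter) from compound 2 to compound 4, 1.2-fold (0.08 log units) apart, within the scatter of two such steps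

Across these four compounds, each change therefore carries from one core to the other at much the same size, but this rests on a single pair of cores in one cell assay, so it does not show that the pattern holds on other cores or explain why either change gives a weaker result.

The compounds shown leave open how a fluoro or methyl group would compare with bromo at that place on the ring. They also leave open what an even longer chain carrying the chloro group would do.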